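This account rests on a few compounds, and the source may have more. Where it says the series, first, only, none or still open, it means among the compounds named here.

Compound 2 `Cn1c(NN)nc(-c2cccs2)c(C#N)c1=O` and compound 1 `CSc1nc(-c2cccs2)c(C#N)c(=O)n1C` share a core, and in a functional assay on microsomes for inhibition, with a stated time of 1 h (on this read-out lower numbers stand for stronger inhibition and higher numbers for weaker inhibition), compound 2 gives 68 ug/mL while compound 1 gives 83 ug/mL. The change between them, (methylsulfanyl in place of aminoamino on an aromatic carbon), made a step of a 1.2-fold higher number from compound 2 to compound 1 (0.09 log units; within the scatter). Compound 3 `Cn1c(NN)nc(-c2cccc(O)c2O)c(C#N)c1=O` carries a different core; the difference between the two cores is not broken down here. In this assay compound 3 gives 31 ug/mL. Compound 4 `CSc1nc(-c2cccc(O)c2O)c(C#N)c(=O)n1C` is not yet measured and differs from compound 3 by methylsulfanyl in place of aminoamino on an aromatic carbon. This is the same kind of change as from compound 2 to compound 1, though the surroundings differ: meta to a thiophen-2-yl group (5 heavy atoms) in the first pair, meta to a group of 8 heavy atoms in the second. Because the earlier step of a 1.2-fold higher number from compound 2 to compound 1 (0.09 log units; within the scatter) stayed within the scatter, a step of about a 1.2-fold higher number from compound 3 to compound 4 (0.09 log units; within the scatter) is expected here, and compound 4 is estimated at 38 ug/mL, between 18 ug/mL and 80 ug/mL.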

Compound 4, half-maximal inhibitory concentration: 41 ug/mL
Beside the measured number, compound 4's estimate is 1.1-fold (0.03 log units) below it; the measured number falls inside the stated range.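

In this assay, putting methylsulfanyl in place of aminoamino gave a 1.3-fold higher number from compound 3 to compound 4 (0.12 log units; within the scatter). Set beside the earlier step, the change carried over from one core to the other with no readable difference: the same change on two cores in this assay, a 1.2-fold higher number (0.09 log units; within the scatter) from compound 2 to compound 1 and a 1.3-fold higher number (0.12 log units; within the scatter) from compound 3 to compound 4, 1.1-fold (0.03 log units) apart, within the scatter of two such steps. For the compounds shown here, this rests on only two pairs, both with steps inside the scatter, so it shows that the change stayed small on these two cores, not that it would stay small on any other core.

The compounds shown leave open whether another group in this place, such as a simple amine or a longer alkylthio chain, would shift the number beyond the scatter. They also leave open what methoxy groups in place of the hydroxyl groups of compound 3 would do.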